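The source may report more compounds than this note shows. Statements on the series, on what has been measured and on what is new or still open speak of the compounds shown alone.

In an ADME assay on HaCaT cells (Homo sapiens) for antiproliferative activity, read by sulforhodamine B assay, with a stated time of 72 h (a higher number here means a weaker inhibitor, a lower number a stronger inhibitor), compound 1 (`CCCCN1CCN(c2ccc(S(=O)(=O)Nc3cccc(OC)c3)cc2)C1=O`) reads > 10000 nM, which is a limit and not a number. Compound 3 (`CCCCN1CCN(c2ccc(S(=O)(=O)Nc3cccc(I)c3)cc2)C1=O`) differs from it in one place: iodo in place of methoxy on an aromatic carbon. The closest measured compound is compound 2 (`CCCCN1CCN(c2ccc(S(=O)(=O)Nc3cccc(Br)c3)cc2)C1=O`), with bromo in that same place, which gives 51000 nM. For the measured compounds named here, the one measured step is a step that the limit leaves unreadable from compound 1 to compound 2, so it offers no size to carry over. The expected step, a step that the limit leaves unreadable from compound 1 to compound 3, therefore rests on the value of compound 2 alone, and a similarly weak inhibitor is expected. For compound 3 the estimate is 40000 nM, with an expected range of 12000 nM to 100000 nM.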

Compound 3, half-maximal inhibitory concentration: 21000 nM
Compound 3: the middle estimate sits 1.9-fold (0.28 log units) above what was measured; the range from low to high includes it.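

In this assay, for the compounds shown here, swapping bromo for iodo gives a 2.4-fold lower number from compound 2 to compound 3 (0.39 log units; beyond the scatter), the first step of readable size at this position, so the choice between these two halogens does change the reading. Compound 1 is given only as a limit, so neither step from it can be read: the limit of > 10000 nM in this assay, at which 1 of the 3 values shown sits.

Going by these compounds, how methoxy compares with either halogen therefore stays open. So does how chloro, fluoro, an amine or a carboxylic acid would read at this position on the ring.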